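The source may hold more compounds than are shown below. What is called first, only, known or untested is meant among the compounds shown, and "the series" means these compounds.

Measured so far in an ADME assay on MT4 cells (Homo sapiens) for cytotoxicity, read by MTT assay, with a stated time of 96 h; on this read-out higher numbers stand for lower toxicity in this test and lower numbers for higher toxicity in this test:
- compound 2, `Nc1ccc(-c2nc3cc(Cl)c(Cl)cc3[nH]2)cc1`, gives 17000 nM
- compound 1, `CN1CCN(CC(=O)Nc2ccc(-c3nc4cc(Cl)c(Cl)cc4[nH]3)cc2)CC1`, gives 11000 nM

Compound 2 and compound 1 give numbers that lie within the usual scatter of each other, so the two cannot be told apart on toxicity here; neither can be called the less toxic one.

Compound 3, `O=C(CN1CCCC1)Nc1ccc(-c2nc3cc(Cl)c(Cl)cc3[nH]2)cc1`, has not yet been measured in this assay. It differs from compound 2 by ((pyrrolidin-1-yl)methyl)carbonyl in place of hydrogen on a nitrogen on an aromatic ring. Compound 1 carries a related amide built from a six-membered ring on the same nitrogen, and its number sits beside that of compound 2. On that basis the step from compound 2 to compound 3 is expected to be small, at most a slight fall, and likely within the scatter: a 1.4-fold lower number from compound 2 to compound 3 (0.15 log units; within the scatter). Compound 3 is therefore estimated at 12000 nM, within a range from 5000 nM to 28000 nM.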

Compound 3, half-maximal cytotoxic concentration: 8000 nM
Estimate against measurement, compound 3: 1.5-fold (0.18 log units) above; low and high end bracket the measured number.
By their numbers in this assay, from the lowest: compounds 3, 1 and 2 (each within the scatter of the next, the first and the last beyond it).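

In this assay the change of ((pyrrolidin-1-yl)methyl)carbonyl in place of hydrogen on the nitrogen gives a 2.1-fold lower number from compound 2 to compound 3 (0.33 log units; beyond the scatter) and so shows that this position can respond to an added amide, modestly and towards higher toxicity in this test. Pyrrolidin-1-yl in place of 4-methylpiperazin-1-yl gives a 1.4-fold lower number from compound 1 to compound 3 (0.14 log units; within the scatter) and leaves these two amides indistinguishable. Compound 1 also carries an amide on this nitrogen yet stays within the scatter of compound 2, so the shift beyond the scatter cannot be claimed for every such amide.

From the compounds shown here alone, it remains open whether a plain acetyl group on the same nitrogen, with no ring-bearing amine at its end, or an open-chain dimethylamino group in place of the pyrrolidine would behave alike. Nothing available here accounts for the shift.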